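The source may hold more compounds than are shown below. What is called first, only, known or untested is meant among the compounds shown, and "the series" means these compounds.

Measured so far in an ADME assay on HEK293 cells (Homo sapiens) for cytotoxicity, with a stated time of 72 h; a lower number here means that less compound is needed, a higher number that more compound is needed for the effect:
- Compound 1 `COC(=O)c1ccc(NC(=O)Nc2cc(C)nc3ccccc23)cc1`: 15000 nM
- Compound 2 `Cc1cc(NC(=O)Nc2ccc(O)cc2)c2ccccc2n1`: > 25000 nM (a limit of the assay, not a number)

Compound 2 has no number and stands only at the limit of > 25000 nM in this assay, at which 1 of the 2 values shown sits. The unmeasured compound 3 `Cc1cc(NC(=O)Nc2ccc(SC(F)(F)F)cc2)c2ccccc2n1` keeps the shared core and carries (trifluoromethyl)sulfanyl in place of hydroxy on an aromatic carbon, para to a large group ((trifluoromethyl)sulfanyl in place of hydroxy on an aromatic carbon).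

Among the compounds with values here, one measured step bears on this change, as it concerns the same place: an at least 1.6-fold higher number from compound 1 to compound 2 (0.22 log units; that floor lies within the scatter). Within the data shown here, that step therefore shows no change beyond the scatter, and it is the only guide available. Compound 1, which has methoxycarbonyl in place of the hydroxy, gives 15000 nM. On that basis, a number for the new group is expected in the same region, although another limit remains possible.

The expected change in this assay is an at least 2.0-fold lower number from compound 2 to compound 3 (0.31 log units; beyond the scatter), a modest step towards a lower number. For compound 3 the estimated value is 12000 nM, with an expected range of 3500 nM to 25000 nM.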

Compound 3, half-maximal effective concentration: 13000 nM
The estimate for compound 3 lay 1.1-fold (0.03 log units) below the measured number, and the stated range covers the measured number.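

In this assay, this place on the aromatic carbon, para to a large group, now carries two different groups that both give a number, and replacing methoxycarbonyl with (trifluoromethyl)sulfanyl produces no change beyond the scatter: the step is a 1.2-fold lower number from compound 1 to compound 3 (0.06 log units; within the scatter) and so gives no order between the two. Replacing hydroxy with (trifluoromethyl)sulfanyl gives an at least 1.9-fold lower number from compound 2 to compound 3 (0.28 log units; that floor lies within the scatter) as the step, so even this change, with more heavy atoms entering and the hydrogen-bond donor leaving, has not been shown to exceed the scatter. Compound 2 remains defined only by a limit of the assay, not a number: the limit of > 25000 nM in this assay, at which 1 of the 3 values shown sits.

From the compounds shown here alone, the true distance of hydroxy from the other two groups stays open, and the data cannot tell whether the hydrogen-bond donor or the size of the group matters at this place. An amine, a carboxylic acid or a longer alkyl chain at the same place would show whether the close values of compound 1 and compound 3 extend beyond these two groups.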